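Fluoro for Methoxy: Expecting Compound 3 on a Shared Core

A few compounds are considered here, and "the series" means these few. Any claim that something is new, unique, unknown or untested is made for them only; others in the source may bear on it.

Compound 1, `COc1ccc(CNc2nc3cc(N)cc(N)c3nc2-c2ccccc2)cc1`: 18200 nM
Compound 2, `COc1ccc(Sc2nc3cc(N)cc(N)c3nc2-c2ccccc2)cc1`: 17000 nM

Of the compounds shown here, two on the shared core have been measured in a functional assay on RXF 393 cells (Homo sapiens) for inhibition, read by sulforhodamine B assay, with a stated time of 48 h; on this read-out higher numbers stand for weaker inhibition of growth and lower numbers for stronger inhibition of growth. Compound 2 gives 17000 nM, and compound 1 gives 18200 nM; the two numbers sit within the usual scatter of each other, so compound 2 stands alongside compound 1 rather than apart from it. Compound 3 `Nc1cc(N)c2nc(-c3ccccc3)c(Sc3ccc(F)cc3)nc2c1` has not yet been measured in this assay. It differs from compound 2 in one place: fluoro in place of methoxy on an aromatic carbon. Among the compounds with values here, no step between measured compounds is available that would show how this change has behaved before, so no direction can be read from the data. The change is small, and compound 2 and compound 1 already show that the two measured compounds on this core fall close together. Compound 3 is therefore expected to stay near compound 2, with an expected step of no change at the digits printed from compound 2 to compound 3 (within the scatter) that does not go beyond the scatter. The estimate for compound 3 is 17000 nM, within a range from 7000 nM to 40000 nM.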

Compound 3, concentration for total growth inhibition: < 100000 nM
Compound 3 ended at the assay's limit (the forecaster's own chance of this, stated with the estimate: 10%); the middle value lies beyond the limit too.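

In this assay compound 3 gives < 100000 nM, which is a limit of the assay and not a number. The step from compound 2 to compound 3 therefore cannot be read: the limit of < 100000 nM in this assay, at which 1 of the 3 values shown sits. The compounds shown leave open how fluoro in place of methoxy on an aromatic carbon affects inhibition of growth on the shared core.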